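The compounds below may be only part of what the source reports. "The series", "measured", "known", "first", "only" and "open" are said of these compounds alone.

Measured in a functional assay on MCF7 cells (Homo sapiens) for inhibition, read by MTT assay; a higher number here means a weaker inhibitor of growth, a lower number a stronger inhibitor of growth:
- compound 1 `CC1=C(/C=C/C(C)=C/C=C/C(C)=C\C(=O)Nc2ccc(O)cc2)C(C)(C)CCC1n1ccnc1`: 1990 nM
- compound 2 `CC1=C(/C=C/C(C)=C/C=C/C(C)=C\C(=O)Nc2ccc(F)cc2)C(C)(C)CCC1n1ccnc1`: 400 nM
- compound 3 `CC1=C(/C=C/C(C)=C/C=C/C(C)=C\C(=O)NCc2ccc(O)cc2)C(C)(C)CCC1n1ccnc1`: 160 nM

Compound 3 has the lowest number of the three, and both a 12-fold lower number from compound 1 to compound 3 (1.09 log units; beyond the scatter) and a 2.5-fold lower number from compound 2 to compound 3 (0.40 log units; beyond the scatter) lie beyond the scatter. Compound 4 `CC1=C(/C=C/C(C)=C/C=C/C(C)=C\C(=O)NCc2ccccc2)C(C)(C)CCC1n1ccnc1` carries hydrogen in place of hydroxy on an aromatic carbon, para to a large group (hydrogen in place of hydroxy on an aromatic carbon). Within the data shown here, no measured step makes this exact change. The nearest is the modest 5.0-fold lower number from compound 1 to compound 2 (0.70 log units; beyond the scatter), where fluoro replaces hydroxy on the ring of the 4-hydroxyphenyl amide rather than the 4-hydroxybenzyl amide. That step points to a small move toward a lower number, though one within the scatter would be no surprise. The expected change is a 1.5-fold lower number from compound 3 to compound 4 (0.16 log units; within the scatter). For compound 4 the estimated value is 110 nM, with an expected range of 40 nM to 320 nM.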

Compound 4, concentration for 50% growth inhibition: 9770 nM
The estimate for compound 4 lay 89-fold (1.95 log units) below the measured number, outside the stated range (above it).
By their numbers in this assay, from the lowest: compound 3; then compound 2; then compound 1; then compound 4.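

Hydrogen in place of hydroxy on the aromatic carbon, para to a large group, gives a 61-fold higher number from compound 3 to compound 4 (1.79 log units; beyond the scatter) on the benzyl amide, whereas fluoro in place of hydroxy on the phenyl amide had lowered the number. The unsubstituted benzyl amide also stands apart from both phenyl amides, with a 24-fold higher number from compound 2 to compound 4 (1.39 log units; beyond the scatter) and a 4.9-fold higher number from compound 1 to compound 4 (0.69 log units; beyond the scatter), so the benzyl linkage alone does not give a low number. Nothing available explains this result.

As far as these compounds go, whether methoxy or an amine in place of the hydroxy on the benzyl ring would keep the number low remains open.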